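Chloro to Hydrogen in a Pair at the Limit

This account rests on a few compounds, and the source may have more. Where it says the series, first, only, none or still open, it means among the compounds named here.

Compound 1 (`Nc1ccccc1NC(=O)c1ccc(COc2ccc(Br)cc2)cc1`) gives > 32000 nM in a functional assay on HepG2 cells (Homo sapiens) for antiproliferative activity, read by CCK-8 assay, with a stated time of 72 h (on this read-out lower numbers stand for stronger inhibition and higher numbers for weaker inhibition), as a limit of the assay. Compound 2 (`Nc1ccccc1NC(=O)c1ccc(COc2ccc(Cl)cc2)cc1`) gives > 32000 nM here too, again a limit. Both sit at the limit of > 32000 nM in this assay, at which 2 of the 2 values shown sit, and neither has a number. Compound 3 (`Nc1ccccc1NC(=O)c1ccc(COc2ccccc2)cc1`) carries hydrogen in place of chloro on an aromatic carbon. Within the data shown here, the only measured step that bears on this (a step that the two limits leave unreadable from compound 1 to compound 2) has no readable size, so it gives no guide to size or direction. No step beyond the scatter is expected, and the estimated change (a number no higher from compound 2 to compound 3 (the limit leaves the size open)) has no firm direction. In this assay compound 3 is expected at 32000 nM (estimated range 12000 nM to 64000 nM).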

Compound 3, half-maximal inhibitory concentration: 6700 nM
For compound 3 the middle estimate is 4.8-fold (0.68 log units) above the measured one; the whole stated range lies above it.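

With hydrogen on this aromatic carbon, the series gains its first readable number in this assay, and the change from chloro gives an at least 4.7-fold lower number from compound 2 to compound 3 (0.67 log units; beyond the scatter). The change from bromo gives an at least 4.7-fold lower number from compound 1 to compound 3 (0.67 log units; beyond the scatter), so neither halogen shown is tolerated as well as hydrogen here. The true size of both steps stays open because compounds 1 and 2 sit at a limit: the limit of > 32000 nM in this assay, at which 2 of the 3 values shown sit.

The step between the two halogens cannot be read. On these data alone, whether a fluoro, a methyl or an amine on this carbon would stay near compound 3 or fall back to the limit remains open.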